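The compounds below may be only part of what the source reports. "The series", "measured", "known", "first", "only" and "open" are said of these compounds alone.

Measured so far in a functional assay on microsomes from liver (Rattus norvegicus, strain Wistar) for inhibition, with a stated time of 15 min; a lower number here means a stronger inhibitor, a higher number a weaker inhibitor:
compound 1 `COc1cc(C2CC(c3cc4ccccc4o3)=NN2C(=O)Nc2ccccc2O)ccc1O` gives 22000000 nM
compound 2 `COc1cc(NC(=O)N2N=C(c3cc4ccccc4o3)CC2c2ccc(O)c(OC)c2)ccc1O` gives 12000000 nM
compound 3 `COc1cc(C2CC(c3cc4ccccc4o3)=NN2C(=O)Nc2ccc(F)cc2)ccc1O` gives 125000000 nM

Compound 3 stands highest of the three numbers in this assay. Its nearest neighbour is compound 1, with a 5.7-fold higher number from compound 1 to compound 3 (0.75 log units; beyond the scatter); compound 2 lies further off, with a 10-fold higher number from compound 2 to compound 3 (1.02 log units; beyond the scatter). The step from compound 1 to compound 2, a 1.8-fold lower number from compound 1 to compound 2 (0.26 log units; within the scatter), is within the scatter.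

Compound 4 `COc1cc(C2CC(c3cc4ccccc4o3)=NN2C(=O)Nc2ccc(C)cc2)ccc1O` differs from compound 3 by methyl in place of fluoro on an aromatic carbon. Going by the values given here, none of the measured steps swaps one small substituent for another at this position; the two steps that touch this ring both exchange whole aryl groups and were modest to large. Among the compounds with values here, no comparable pair exists, so no step beyond the scatter is expected; the estimated change is a 1.3-fold lower number from compound 3 to compound 4 (0.10 log units; within the scatter). Compound 4 is expected to give 100000000 nM in this assay, within 30000000 nM to 300000000 nM.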

Compound 4, half-maximal inhibitory concentration: 44000000 nM
Compound 4: the middle estimate sits 2.3-fold (0.36 log units) above what was measured; the measured number falls inside the stated range.
By their numbers in this assay, from the lowest: compounds 2, 1 and 4 (each within the scatter of the next, the first and the last beyond it); then compound 3.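

In this assay, methyl in place of fluoro on this aromatic carbon gives a 2.8-fold lower number from compound 3 to compound 4 (0.45 log units; beyond the scatter) and shows that this position responds to an exchange of one small substituent, not only to exchange of whole aryl groups. With the 4-methylphenyl group, a 3.7-fold higher number from compound 2 to compound 4 (0.56 log units; beyond the scatter) remains beyond the scatter, whereas a 2.0-fold higher number from compound 1 to compound 4 (0.30 log units; within the scatter) lies within it. No available evidence bears on the reason for this change.

Only fluoro and methyl can be compared directly at this position. On these data alone, how an amine, a carboxylic acid or a longer chain there would read remains open.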